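Working notes: from compound 3 to compound 4

The compounds below may be only part of what the source reports. "The series", "measured", "known", "first", "only" and "open" are said of these compounds alone.

- compound 1 `CCOc1ccc(-c2ccc3ncn(-c4cc(OC)c(OC)c(OC)c4)c3c2)cc1`: 2970 nM
- compound 2 `COc1cc(-n2cnc3ccc(-c4cc(F)ccc4F)cc32)cc(OC)c1OC`: 6590 nM
- compound 3 `COc1cc(-n2cnc3ccc(-c4ccc(C(F)(F)F)cc4)cc32)cc(OC)c1OC`: 890 nM

All three values come from a functional assay on SGC-7901 cells (Homo sapiens) for antiproliferative activity, read by MTT assay, with a stated time of 72 h; a higher number here means a weaker inhibitor, a lower number a stronger inhibitor. Among them, compound 3 has the lowest number, at 890 nM. The unmeasured compound 4 `COc1cc(-n2cnc3ccc(-c4cccc(O)c4)cc32)cc(OC)c1OC` differs from it at one place: 3-hydroxyphenyl in place of 4-(trifluoromethyl)phenyl on an aromatic carbon. In words, this is 3-hydroxyphenyl in place of 4-(trifluoromethyl)phenyl on an aromatic carbon.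

Three measured steps change this same group: a 3.3-fold lower number from compound 1 to compound 3 (0.52 log units; beyond the scatter), a 2.2-fold higher number from compound 1 to compound 2 (0.35 log units; beyond the scatter) and a 7.4-fold lower number from compound 2 to compound 3 (0.87 log units; beyond the scatter). All are modest and beyond the scatter. Among the measured compounds shown here, no measured compound carries 3-hydroxyphenyl, so the evidence is indirect. Compound 1 at 2970 nM and compound 2 at 6590 nM both stand higher than compound 3, so a modest rise is expected in this assay. The expected step is a 2.8-fold higher number from compound 3 to compound 4 (0.45 log units; beyond the scatter). Compound 4 is estimated at 2500 nM, with an expected range of 800 nM to 8000 nM.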

Compound 4, half-maximal inhibitory concentration: 53 nM
Compound 4: middle estimate off by 47-fold (1.67 log units), on the high side, outside the stated range (below it).
By their numbers in this assay, from the lowest: compound 4; then compound 3; then compound 1; then compound 2.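

In this assay, among the compounds shown here, the choice of aryl group at this position moves the number much further than the earlier compounds showed: a 17-fold lower number from compound 3 to compound 4 (1.23 log units; beyond the scatter) and a 120-fold lower number from compound 2 to compound 4 (2.09 log units; beyond the scatter) and a 56-fold lower number from compound 1 to compound 4 (1.75 log units; beyond the scatter) are all large, while the steps among the earlier three were modest. Compound 4, with 3-hydroxyphenyl, is therefore the strongest of the four. Nothing at hand accounts for this gain.

Open, as far as these compounds go, is whether the hydroxy group itself carries the gain, or whether a methoxy group, an amine or a carboxylic acid in its place would match it.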